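Sulfonamide-triazole series: aryl ether extension, cytotoxicity notes

The source may report more compounds than this note shows. Statements on the series, on what has been measured and on what is new or still open speak of the compounds shown alone.

Measured so far:
compound 1 `O=Cc1ccc(OCc2cn(-c3ccc(S(=O)(=O)N4CCc5ccccc5C4)cc3)nn2)cc1`: 5270 nM
compound 2 `O=S(=O)(c1ccc(-n2cc(COc3ccccc3)nn2)cc1)N1CCc2ccccc2C1`: 6500 nM

Among the measured compounds shown here, in a functional assay on HepG2 cells (Homo sapiens) for cytotoxicity, read by MTT assay, with a stated time of 48 h (a lower number here means a stronger inhibitor, a higher number a weaker inhibitor), compound 2 gives 6500 nM, the higher of the two numbers recorded, with compound 1 as its only neighbour. For the measured compounds named here, the single measured step, a 1.2-fold higher number from compound 1 to compound 2 (0.09 log units; within the scatter), is within the scatter, so the two values are treated as equivalent.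

Compound 3 `O=S(=O)(c1ccc(-n2cc(COc3ccc4ccccc4c3)nn2)cc1)N1CCc2ccccc2C1` differs from compound 2 by naphthalen-2-yl in place of phenyl on an oxygen on a saturated carbon. Going by the values given here, no measured step touches this part of the structure; the one step recorded, a 1.2-fold higher number from compound 1 to compound 2 (0.09 log units; within the scatter), concerns the other end of the molecule and does not bear on the change. Among the compounds with values here, with no direct precedent, the working expectation is no step beyond the scatter, and the expected step of a 1.2-fold lower number from compound 2 to compound 3 (0.07 log units; within the scatter) reflects that.

Compound 3 is therefore estimated at 5500 nM in this assay, with a range from 2200 nM to 14000 nM, the width of the range reflecting the absence of any comparable measured change.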

Compound 3, half-maximal inhibitory concentration: 60500 nM
The estimate for compound 3 lay 11-fold (1.04 log units) below the measured number; measured number above the stated range.
By their numbers in this assay, from the lowest: compounds 1 and 2 (each within the scatter of the next); then compound 3.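

In this assay, among the compounds shown here, the aryl group on the ether oxygen is the first place where a change moves the number beyond the scatter: naphthalen-2-yl in place of phenyl gives a 9.3-fold higher number from compound 2 to compound 3 (0.97 log units; beyond the scatter), and naphthalen-2-yl in place of 4-formylphenyl gives an 11-fold higher number from compound 1 to compound 3 (1.06 log units; beyond the scatter). Formyl against hydrogen on the phenyl ring had separated nothing, so going from one six-membered aromatic ring to 2 such rings at this position matters more here than the formyl group does. No supporting data bear on the reason for the rise.

On these data alone, whether the rise is specific to naphthalen-2-yl or would also appear with naphthalen-1-yl remains open. Also open, as far as these compounds go, is whether a polar group on the phenyl ring, such as an amine or a carboxylic acid, would move the number beyond the scatter where formyl did not.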